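Aryl variation on a semicarbazone series: compounds 1, 2 and 3

The source may report more compounds than this note shows. Statements on the series, on what has been measured and on what is new or still open speak of the compounds shown alone.

Measured so far:
compound 1, `N#Cc1ccc(/C=N/NC(=O)Nc2ccc(Oc3ccnc4[nH]ccc34)c(F)c2)cc1`: 1360 nM
compound 2, `O=C(N/N=C/c1ccc(O)cc1O)Nc1ccc(Oc2ccnc3[nH]ccc23)c(F)c1`: 5840 nM

In a functional assay on A549 cells (Homo sapiens) for antiproliferative activity, read by MTT assay, with a stated time of 72 h (on this read-out higher numbers stand for weaker inhibition and lower numbers for stronger inhibition), compound 1 gives 1360 nM and stands as the lower of the two numbers recorded; its nearest neighbour is compound 2, where the change of 2,4-dihydroxyphenyl in place of 4-cyanophenyl on a carbon with a double bond to nitrogen gave a 4.3-fold higher number from compound 1 to compound 2 (0.63 log units; beyond the scatter).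

Compound 3, `O=C(N/N=C/c1cc(Br)c(O)c(Br)c1)Nc1ccc(Oc2ccnc3[nH]ccc23)c(F)c1`, is not yet measured. It differs from compound 1 as follows: 3,5-dibromo-4-hydroxyphenyl in place of 4-cyanophenyl on a carbon with a double bond to nitrogen. Among the compounds with values here, the only measured step touching the same place is the one from compound 1 to compound 2, which was beyond the scatter and toward a weaker number. Compound 3 keeps one hydroxyl on the ring but carries two bromines instead of a second hydroxyl, so a shift in the same direction but of uncertain size is expected, giving a 1.8-fold higher number from compound 1 to compound 3 (0.26 log units; within the scatter). For compound 3 the estimate in this assay is 2500 nM, within a range from 800 nM to 8000 nM.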

Compound 3, half-maximal inhibitory concentration: 16200 nM
Compound 3: the middle estimate sits 6.5-fold (0.81 log units) below what was measured; measured number outside the range, above it.
By their numbers in this assay, from the lowest: compound 1; then compound 2; then compound 3.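

In this assay, within the data shown here, this place on the carbon with a double bond to nitrogen spans a wider range than the first pair suggested, with 3,5-dibromo-4-hydroxyphenyl in place of 4-cyanophenyl giving the largest step so far (a 12-fold higher number from compound 1 to compound 3 (1.08 log units; beyond the scatter)). Keeping a hydroxyl on the ring does not hold the number at the level of the 2,4-dihydroxyphenyl analogue (a 2.8-fold higher number from compound 2 to compound 3 (0.44 log units; beyond the scatter)), so the presence of a hydroxyl alone does not set the value among these compounds. No measurement at hand accounts for this order of the three aryl groups.

The compounds shown do not separate the contribution of the two bromines from that of the hydroxyl in 3,5-dibromo-4-hydroxyphenyl. Also open, as far as these compounds go, is how a ring bearing a dimethylamino group or a carboxylic acid would stand at this place.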